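Dropping the methylamino group from compound 3

A few compounds are considered here, and "the series" means these few. Any claim that something is new, unique, unknown or untested is made for them only; others in the source may bear on it.

Measured so far:
compound 1 `CNc1nc(N2CC(N(C)C)C2)nc2ccc(Cl)cc12`: 468 nM
compound 2 `CN1CCN(c2ncc3cc(Cl)ccc3n2)CC1`: 7.41 nM
compound 3 `CNc1nc(N2CCN(C)CC2)nc2ccccc12`: 2.95 nM

In an assay on HEK293 cells for displacement of a labelled ligand from 5-hydroxytryptamine receptor 3A (Homo sapiens), read by scintillation counting, with a stated time of 24 h, in the presence of a further agent that is not named here (a lower number here means a stronger inhibitor, a higher number a weaker inhibitor), compound 3 gives 2.95 nM, the lowest of the three numbers. Its nearest neighbour is compound 2 at 7.41 nM, a gap beyond the usual scatter; compound 1 at 468 nM lies far higher. Among the compounds with values here, no two measured compounds differ in a single place, so none of these gaps can be read as a clean step.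

Compound 4 `CN1CCN(c2ncc3ccccc3n2)CC1` differs from compound 3 by hydrogen in place of methylamino on an aromatic carbon. Within the data shown here, the change has no direct precedent among the measured pairs. Compound 2, which also carries no methylamino group on the same core position, gives 7.41 nM, which suggests the group is not essential for a low number. The step from compound 3 to compound 4 is therefore expected to be small, a 2.0-fold higher number from compound 3 to compound 4 (0.31 log units; beyond the scatter), at most a modest weakening and possibly none beyond the scatter. Compound 4 is estimated at 6 nM, within a range of 1.5 nM to 25 nM.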

Compound 4, inhibition constant: 1.35 nM
For compound 4 the middle estimate is 4.4-fold (0.65 log units) above the measured one; measured number below the stated range.
By their numbers in this assay, from the lowest: compound 4; then compound 3; then compound 2; then compound 1.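

In this assay the methylamino group on the aromatic carbon next to the ring nitrogen proves unnecessary for a low number, and hydrogen there gives the lower value (a 2.2-fold lower number from compound 3 to compound 4 (0.34 log units; beyond the scatter)). Removing chloro from the shared core points the same way (a 5.5-fold lower number from compound 2 to compound 4 (0.74 log units; beyond the scatter)), so in both single changes among these compounds the bare core gives the lower number, and no listed step goes against this. Nothing measured here accounts for either step.

Still open, from the compounds shown here alone, is whether any group at the methylamino place can improve on hydrogen, for instance a plain amino group, a methoxy group or a longer chain such as ethylamino. Going by these compounds, it is also open whether chloro and methylamino together on the core of compound 3 would add up or behave differently from each alone.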